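The source may hold more compounds than are shown below. What is called first, only, known or untested is meant among the compounds shown, and "the series" means these compounds.

Compound 1 `COC(=O)c1ccccc1OCc1oc(-c2cccc(OC)c2)nc1C` and compound 3 `COc1cccc(-c2nc(C)c(COc3ccccc3C(=O)O)o2)c1` share one core, and compound 3 carries hydrogen in place of methyl on an oxygen next to a carbonyl group. In a physicochemical assay for solubility, tested at 500 uM (a higher number here means a more soluble compound, a lower number a less soluble compound), compound 1 gives 52800 nM, and compound 3 gives 264000 nM, which is a 5.0-fold higher number from compound 1 to compound 3 (0.70 log units; beyond the scatter). Compound 2 `COC(=O)c1cccc(OCc2oc(-c3ccccc3OC)nc2C)c1` is built from the same atoms as compound 1, joined differently; the difference between the two cores is not broken down here. In this assay compound 2 gives 44100 nM, a number within the scatter of that for compound 1. Compound 4 `COc1ccccc1-c1nc(C)c(COc2cccc(C(=O)O)c2)o1` is the unmeasured partner of compound 2 and carries the same change, (hydrogen in place of methyl on an oxygen next to a carbonyl group), on an oxygen next to a carbonyl group. A step of about the same size is expected here, because a 5.0-fold higher number from compound 1 to compound 3 (0.70 log units; beyond the scatter) followed this very change. For compound 4 a value of 220000 nM is estimated, with a range from 80000 nM to 500000 nM. That estimate means a step of a 5.0-fold higher number from compound 2 to compound 4 (0.70 log units; beyond the scatter) is expected.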

Compound 4, solubility: 423000 nM
Compound 4: the middle estimate sits 1.9-fold (0.28 log units) below what was measured; low and high end bracket the measured number.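

In this assay, the change from methoxycarbonyl to carboxy gives a 9.6-fold higher number from compound 2 to compound 4 (0.98 log units; beyond the scatter), while on the other core it gave a 5.0-fold higher number from compound 1 to compound 3 (0.70 log units; beyond the scatter). Both steps run the same way and both lie beyond the scatter, so the direction of the change carried over from one core to the other. Two pairs do not establish a rule for further cores, and nothing shown here explains why the number rises.

The compounds shown leave open what an amide or a longer ester, such as ethoxycarbonyl, would give in place of the carboxy group. They also leave open whether the same step would appear on a core with a different substituent.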